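Methyl in place of hydrogen on selenium: expected potency

The compounds below may be only part of what the source reports. "The series", "measured", "known", "first", "only" and "open" are said of these compounds alone.

Two members of the series have so far been run in a functional assay on CCRF-CEM cells (Homo sapiens) for cytotoxicity, read by MTT assay, with a stated time of 72 h; a higher number here means a weaker inhibitor of growth, a lower number a stronger inhibitor of growth. Compound 1 `COc1ccc(CNc2nc([Se]C)nc3ccccc23)cc1` gives > 100000 nM in this assay, which is a limit of the assay and not a number. Compound 2 `[SeH]c1nc(NCc2ccccc2)c2ccccc2n1` gives > 100000 nM in this assay, again a limit rather than a number. For the measured compounds named here, compound 2 therefore stands at the limit, and it does not stand there alone: both values shown sit at the limit of > 100000 nM in this assay, at which 2 of the 2 values shown sit, so the measured part of the series yields no ordering and no step between measured compounds can be drawn.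

Compound 3 `C[Se]c1nc(NCc2ccccc2)c2ccccc2n1` is the next compound, not yet measured. It differs from compound 2 by methyl in place of hydrogen on a selenium. Compound 1 carries the same methyl on a selenium and is also at the limit, though its benzyl group differs from that of compound 3, so its value shows only that a methyl on a selenium did not, in that case, bring growth inhibition into the measurable range. No step beyond the usual scatter is expected here, namely a number no higher from compound 2 to compound 3 (the limit leaves the size open) in this assay. Compound 3 is expected to come out near 100000 nM, within a range from 30000 nM to 300000 nM, most probably reported once more as a limit.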

Compound 3, concentration for 50% growth inhibition: 39800 nM
Beside the measured number, compound 3's estimate is 2.5-fold (0.40 log units) above it; the measured number falls inside the stated range.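

Methyl in place of hydrogen on the selenium brings an at least 2.5-fold lower number from compound 2 to compound 3 (0.40 log units; beyond the scatter) in this assay, the first step in the series that can be read and the first sign that this position responds to a change. Compound 1 carries the same methyl on a selenium and gives > 100000 nM, which is a limit of the assay, so the methyl is not enough on its own to give a measurable value. Hydrogen in place of methoxy on an aromatic carbon brings an at least 2.5-fold lower number from compound 1 to compound 3 (0.40 log units; beyond the scatter), which shows that the measurable value of the methyl compound also depends on this second place in the molecule.

The true size of both steps stays open because each starts from a limit rather than a number: the limit of > 100000 nM in this assay, at which 2 of the 3 values shown sit. The compounds shown also leave open whether a longer chain such as ethyl or propyl on the selenium, or an amine or a carboxylic acid carried on such a chain, would lower the number further or return it to the limit.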